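This account rests on a few compounds, and the source may have more. Where it says the series, first, only, none or still open, it means among the compounds named here.

Measured compounds:
- compound 1 `Cc1nc(-c2cccnc2)sc1-c1nnc(-c2ccccc2Cl)o1` gives > 100 ug/mL in an ADME assay on HCT-116 cells (Homo sapiens) for cytotoxicity, read by MTT assay (on this read-out higher numbers stand for lower toxicity in this test and lower numbers for higher toxicity in this test), a limit of the assay.
- compound 2 `Cc1nc(-c2cccnc2)sc1-c1nnc(-c2ccccc2)o1` gives > 100 ug/mL in this assay, again a limit.
- compound 3 `Cc1nc(-c2cccnc2)sc1-c1nnc(-c2cccc(Cl)c2Cl)o1` gives > 100 ug/mL in this assay, also a limit.

Compound 1 therefore stands only at a limit, and the same is true of the two other measured compounds, as the limit of > 100 ug/mL in this assay, at which 3 of the 3 values shown sit, records. Compound 4 `Cc1ccccc1-c1nnc(-c2sc(-c3cccnc3)nc2C)o1` has not yet been measured. It differs from compound 1 in one place (methyl in place of chloro on an aromatic carbon). For the measured compounds named here, no measured step exchanges chloro for methyl, so the nearest guides are the steps that touch the same ring: from compound 1 to compound 2 a step that the two limits leave unreadable from compound 1 to compound 2, from compound 1 to compound 3 a step that the two limits leave unreadable from compound 1 to compound 3 and from compound 2 to compound 3 a step that the two limits leave unreadable from compound 2 to compound 3. All three are unreadable, because every value involved sits at the limit (the limit of > 100 ug/mL in this assay, at which 3 of the 3 values shown sit). Removing or adding chloro on this ring has not brought any compound below the limit, so no step beyond the scatter is expected here in either direction. Compound 4 is expected to remain at the limit as well, estimated at 150 ug/mL with a range from 80 ug/mL to 400 ug/mL. The expected step from compound 1 to compound 4 is a step that the limit leaves unreadable from compound 1 to compound 4, meaning no readable change.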

Compound 4, half-maximal cytotoxic concentration: > 100 ug/mL
Compound 4 ended at the assay's limit; the forecaster's own chance of this, stated with the estimate: 85%; the middle value does not contradict the limit.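

No step can be read between compound 4 and compound 1, compound 2 or compound 3, because all four compounds stand only at a limit of the assay: the limit of > 100 ug/mL in this assay, at which 4 of the 4 values shown sit.

The compounds shown leave open how far apart their true values lie in this assay, and whether chloro, methyl or hydrogen on this ring makes any difference there.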